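This account rests on a few compounds, and the source may have more. Where it says the series, first, only, none or still open, it means among the compounds named here.

Of the compounds shown here, three have been measured so far. Compound 1 `O=C(Nc1ccc(Oc2ccnc3[nH]ccc23)cc1)c1nn(-c2ccccc2)ccc1=O` gives 17800 nM in a functional assay on HepG2 cells (Homo sapiens) for cytotoxicity, read by MTT assay, with a stated time of 72 h; on this read-out higher numbers stand for weaker inhibition and lower numbers for stronger inhibition. Compound 2 `O=C(Nc1ccc(Oc2ccnc3[nH]ccc23)cc1)c1nn(-c2ccc(Br)cc2F)ccc1=O` gives 46400 nM in this assay. Compound 3 `Cn1ccc2c(Oc3ccc(NC(=O)c4nn(-c5ccccc5)ccc4=O)cc3F)ccnc21` reaches only a limit of the assay in this assay, at > 60000 nM.

Compounds 1 and 2 share one core and differ in a single place, the change being (4-bromo-2-fluorophenyl in place of phenyl on an aromatic nitrogen). This step gave a 2.6-fold higher number from compound 1 to compound 2 (0.42 log units; beyond the scatter). Compound 3 sits on a different core; how it differs from compound 1 is not broken down here. Compound 4 `Cn1ccc2c(Oc3ccc(NC(=O)c4nn(-c5ccc(Br)cc5F)ccc4=O)cc3F)ccnc21`, not yet measured, is related to compound 3 by the same change, (4-bromo-2-fluorophenyl in place of phenyl on an aromatic nitrogen), made at a place described in identical words in both pairs.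

Compound 3 already sits at a limit of the assay, as noted in the limit of > 60000 nM in this assay, at which 1 of the 3 values shown sits. Since the same change weakened compound 1 into compound 2 by a 2.6-fold higher number from compound 1 to compound 2 (0.42 log units; beyond the scatter), compound 4 is expected to be no stronger than compound 3 and most likely to return only a limit again. The step from compound 3 to compound 4 is estimated at a step that the limit leaves unreadable from compound 3 to compound 4. Compound 4 is therefore estimated at 120000 nM, in a range from 50000 nM to 400000 nM.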

Compound 4, half-maximal inhibitory concentration: 24000 nM
The estimate for compound 4 lay 5.0-fold (0.70 log units) above the measured number; the measured number lies below the stated range.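

In this assay, within the data shown here, 4-bromo-2-fluorophenyl in place of phenyl gave an at least 2.5-fold lower number from compound 3 to compound 4 (0.39 log units; beyond the scatter), a move opposite in direction to the one the same change gave on the other core: the same change on two cores in this assay, a 2.6-fold higher number (0.42 log units; beyond the scatter) from compound 1 to compound 2 and an at least 2.5-fold lower number (0.39 log units; beyond the scatter) from compound 3 to compound 4, at least 6.5-fold (0.81 log units) apart, beyond the scatter of two such steps. Compound 3 stands only at a limit of the assay, > 60000 nM, so the full size of this step cannot be read: the limit of > 60000 nM in this assay, at which 1 of the 4 values shown sits. The effect of the change therefore did not carry from one core to the other in these two pairs, even in direction, but one pair on each core does not show which difference between the cores goes with the reversal, nor whether it extends to other compounds in the series.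

The compounds shown leave open whether the bromine or the fluorine alone on the phenyl ring would give the same split between the two cores. They also leave open how either core would respond to a methyl group, a morpholine or a carboxylic acid on that aromatic nitrogen.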